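This account rests on a few compounds, and the source may have more. Where it says the series, first, only, none or still open, it means among the compounds named here.

For the measured compounds named here, the three compounds measured so far share one core and differ only in the group carried on the ring nitrogen. Compound 1 `CCCCCN1CCC(NC(=O)c2cc(Cl)c(N)cc2OC)CC1` gives 25.1 nM in a functional assay on HEK293 cells for agonist activity at 5-hydroxytryptamine receptor 4 (Homo sapiens), read by cAMP accumulation; on this read-out lower numbers stand for an effect already at smaller amounts and higher numbers for an effect only at larger amounts of compound. Compound 2 `COc1cc(N)c(Cl)cc1C(=O)NC1CCN(CCCCCCCCO)CC1` gives 15.9 nM in this assay, and the step of a 1.6-fold lower number from compound 1 to compound 2 (0.20 log units; within the scatter) lies within the scatter. Compound 3 `COc1cc(N)c(Cl)cc1C(=O)NC1CCN(CCN2CCCCC2)CC1` gives 100 nM in this assay, the highest number of the three: it stands a 4.0-fold higher number from compound 1 to compound 3 (0.60 log units; beyond the scatter) and a 6.3-fold higher number from compound 2 to compound 3 (0.80 log units; beyond the scatter).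

Compound 4 `COc1cc(N)c(Cl)cc1C(=O)NC1CCN(CCCCCN2CCCCC2)CC1` is not yet measured. It differs from compound 3 in that (3-(piperidin-1-yl)propyl in place of piperidin-1-yl on a saturated chain carbon, two bonds along the chain from an amine nitrogen in a ring). The change thus puts a three-carbon spacer between the ring nitrogen and the terminal piperidine, so that the chain regains something of the length seen in compound 1 and compound 2, which both sit well below compound 3 in this assay.

The two steps that bear on this, a 4.0-fold higher number from compound 1 to compound 3 (0.60 log units; beyond the scatter) and a 6.3-fold higher number from compound 2 to compound 3 (0.80 log units; beyond the scatter), both show that the short piperidinyl group brings a higher number than a longer saturated chain. Lengthening the chain in compound 4 is therefore expected to move the number back down, by roughly the size of those steps, giving an estimated step of a 4.0-fold lower number from compound 3 to compound 4 (0.60 log units; beyond the scatter). Compound 4 is estimated at 25 nM, with a range from 8 nM to 80 nM.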

Compound 4, half-maximal effective concentration: 5.01 nM
Beside the measured number, compound 4's estimate is 5.0-fold (0.70 log units) above it; measured number below the stated range.
By their numbers in this assay, from the lowest: compound 4; then compounds 2 and 1 (each within the scatter of the next); then compound 3.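

With the piperidin-1-yl group kept at the chain end, lengthening the chain alone gives a 20-fold lower number from compound 3 to compound 4 (1.30 log units; beyond the scatter) in this assay, so the high number of compound 3 cannot be read as an effect of the piperidin-1-yl group as such. The end of the longer chain also proves to matter: a 5.0-fold lower number from compound 1 to compound 4 (0.70 log units; beyond the scatter) and a 3.2-fold lower number from compound 2 to compound 4 (0.50 log units; beyond the scatter) both lie beyond the scatter, whereas the step from compound 1 to compound 2 had shown no change beyond it, and compound 4 is the first of these compounds whose number stands clear of all the others. What lies behind these steps cannot be said from the data at hand.

From the compounds shown here alone, it remains open how the number responds to chains of other lengths ahead of the piperidin-1-yl group, and whether a still longer chain would lower it further or raise it again. Also open, going by these compounds, is whether the piperidin-1-yl group at the chain end could be replaced by a morpholin-4-yl, a pyrrolidin-1-yl or an open-chain dimethylamino group with a similar result in this assay.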